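Benzylamino in Place of Pentylselanyl on the Shared Core

The source may report more compounds than this note shows. Statements on the series, on what has been measured and on what is new or still open speak of the compounds shown alone.

Compound 3 `CCCCC[Se]c1nc([Se]CCCCC)c2ccccc2n1` stands in a functional assay on MCF7 cells (Homo sapiens) for cytotoxicity, read by MTT assay, with a stated time of 72 h (a lower number here means that less compound is tolerated, a higher number that more compound is tolerated), only at a limit, > 100000 nM. Compound 2 `Nc1nc([SeH])nc2ncccc12` likewise reaches only the limit > 100000 nM in this assay. Compound 1 `CCCCC[Se]c1nc(N)c2ccccc2n1` gives a number in this assay, 90400 nM. Within the data shown here, the single measured step, an at least 1.1-fold higher number from compound 1 to compound 3 (0.04 log units; that floor lies within the scatter), lies within the scatter, and the limit of > 100000 nM in this assay, at which 2 of the 3 values shown sit, is where compound 3 sits. Compound 4 `CCCCC[Se]c1nc(NCc2ccccc2)c2ccccc2n1` differs from compound 3 by a group of 8 heavy atoms (7 carbon, 1 nitrogen; one six-membered aromatic ring of carbon only) in place of a group of 6 heavy atoms (5 carbon, 1 selenium; no ring), on an aromatic carbon. Among the measured compounds shown here, the only measured step that bears on this change is an at least 1.1-fold higher number from compound 1 to compound 3 (0.04 log units; that floor lies within the scatter), which was within the scatter, so no step beyond the scatter is expected in this assay. Compound 4 is therefore estimated at 85000 nM, with a range from 30000 nM to 200000 nM. The step of an at least 1.1-fold lower number from compound 3 to compound 4 (0.07 log units; that floor lies within the scatter) this estimate implies is expected to stay within the scatter.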

Compound 4, concentration lethal to 50% of the cells: 99400 nM
For compound 4 the middle estimate is 1.2-fold (0.07 log units) below the measured one; the measured number falls inside the stated range.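

Compound 4 shows that benzylamino at this position, in place of pentylselanyl, still gives a readable number, and this change gives a number no higher from compound 3 to compound 4 (the limit leaves the size open). Benzyl in place of hydrogen on the nitrogen gives a 1.1-fold higher number from compound 1 to compound 4 (0.04 log units; within the scatter), so this change leaves the number within the scatter. The compounds shown stay at the edge of what this assay reads: the limit of > 100000 nM in this assay, at which 2 of the 4 values shown sit.

Going by these compounds, it remains open whether a carboxylic acid or a piperazine at this position would give a step beyond the scatter. On these data alone, whether a longer chain in place of pentylselanyl would do so also remains open.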